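The compounds below may be only part of what the source reports. "The series", "measured", "known", "first", "only" and "open" are said of these compounds alone.

Of the compounds shown here, three built on a shared core have been measured in a physicochemical assay for lipophilicity; on this read-out higher numbers stand for higher lipophilicity and lower numbers for lower lipophilicity. Compound 1 `C#CCCOC(=O)/C=C(C)/C=C/CC(C)CCCC(C)(C)OC` gives 5.2, the lowest of the three. Compound 2 `COC(CCC(C)C/C=C/C(C)=C/C(=O)OC(C)C)C(C)C` gives 5.95, a step above compound 1 that lies beyond the scatter, and compound 3 `CCN(CC)C(=O)/C=C(C)/C=C/CC(C)CCCC(C)C` gives 6.02, the furthest above compound 1, also beyond the scatter. Compound 4 `COC(C)(C)CCCC(C)C/C=C/C(C)=C/C(=O)NC(C)C` has not yet been measured. It differs from compound 1 in one place: isopropylamino in place of (but-3-yn-1-yl)oxy on a carbonyl carbon. For the measured compounds named here, no pair of measured compounds differs in a single place, so no measured step tells the size of this change. The starting point is the value of compound 1, 5.2. The change is expected to lower this assay clearly beyond the scatter, a number 0.90 log units lower from compound 1 to compound 4 (beyond the scatter). Compound 4 is therefore estimated at 4.3, within a range from 3.6 to 5.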

Compound 4, partition coefficient: 4.45
Estimate against measurement, compound 4: 0.15 log units below, within the range that was stated.
By their numbers in this assay, from the lowest: compound 4; then compound 1; then compounds 2 and 3 (each within the scatter of the next).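

In this assay, for the compounds shown here, the exchange of (but-3-yn-1-yl)oxy for isopropylamino on a carbonyl carbon now has a measured size, a number 0.75 log units lower from compound 1 to compound 4 (beyond the scatter), the first single-place step in this set. It shows that this position can shift the read-out beyond the scatter. No available evidence bears on what lies behind this step.

Going by these compounds, the step replaces the linking atom and the chain together, so their separate shares remain open. A (but-3-yn-1-yl)amino group at this carbonyl carbon would bear on that split, while a cyclopropylamino group would extend the comparison.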